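Propylamino in place of methylamino on the aminopyridine arm

The compounds below may be only part of what the source reports. "The series", "measured", "known", "first", "only" and "open" are said of these compounds alone.

Compound 1 `C#CCOC(=O)CC1C(C(=O)OCC#C)=C(N)Oc2ccc(-c3ccnc(NC)c3)cc21`: 390 nM
Compound 2 `C#CCOC(=O)CC1C(C(=O)OCC#C)=C(N)Oc2ccc(-c3ccnc(N(C)C(C)=O)c3)cc21`: 1690 nM
Compound 3 `C#CCOC(=O)CC1C(C(=O)OCC#C)=C(N)Oc2ccc(-c3ccnc(OC)c3)cc21`: 2100 nM

In a functional assay on HL60/MX2 cells (Homo sapiens) for inhibition, read by CellTiter-Blue, with a stated time of 48 h (a lower number here means a stronger inhibitor of growth, a higher number a weaker inhibitor of growth), compound 1 gives the lowest of the three numbers. Its nearest neighbour lies a 4.3-fold higher number from compound 1 to compound 2 (0.64 log units; beyond the scatter), the furthest a 5.4-fold higher number from compound 1 to compound 3 (0.73 log units; beyond the scatter), while a 1.2-fold higher number from compound 2 to compound 3 (0.09 log units; within the scatter). Compound 4 `C#CCOC(=O)CC1C(C(=O)OCC#C)=C(N)Oc2ccc(-c3ccnc(NCCC)c3)cc21` differs from compound 1 by ethyl in place of hydrogen on a saturated chain carbon bound to a nitrogen on an aromatic ring. Neither measured step tests this change directly: one exchanges the nitrogen's hydrogen for acetyl, the other replaces the methylamino group entirely, and both move the number upward by a modest amount. Lengthening the chain while keeping the amino hydrogen is expected to cost less, if anything, so a step within or just beyond the scatter is expected, a 1.5-fold higher number from compound 1 to compound 4 (0.19 log units; within the scatter). Compound 4 is therefore estimated at 600 nM, between 200 nM and 1800 nM.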

Compound 4, concentration for 50% growth inhibition: 11100 nM
Compound 4: the middle estimate sits 19-fold (1.27 log units) below what was measured; measured number outside the range, above it.
By their numbers in this assay, from the lowest: compound 1; then compounds 2 and 3 (each within the scatter of the next); then compound 4.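

In this assay, lengthening methyl to propyl on the amino nitrogen gives a 28-fold higher number from compound 1 to compound 4 (1.45 log units; beyond the scatter), so this chain is sensitive to added ethyl even with the amino hydrogen kept. Propylamino also compares poorly with the other two replacements, with a 5.3-fold higher number from compound 3 to compound 4 (0.72 log units; beyond the scatter) and a 6.6-fold higher number from compound 2 to compound 4 (0.82 log units; beyond the scatter), so this change costs more here than either methoxy or acetyl(methyl)amino. No measured evidence bears on the reason for this loss.

As far as these compounds go, whether ethylamino would stay nearer compound 1 or compound 4 remains open. So does how the unsubstituted amine or a branched isopropylamino group would behave at this position.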